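Fluoro for hydrogen on compound 2

The source may hold more compounds than are shown below. What is called first, only, known or untested is meant among the compounds shown, and "the series" means these compounds.

Among the measured compounds shown here, in a functional assay (aorta) with Oryctolagus cuniculus as the target (a higher number here means weaker binding, a lower number tighter binding), compound 2 `COc1cc(C(C)=O)ccc1OCCCN1CCC(C(c2ccccc2)c2ccccc2)CC1` gives 6.31 nM, the higher of the two numbers so far. Compound 1 `COc1cc(C(C)=O)ccc1OCCCN1CCC(C(c2ccc(F)cc2)c2ccc(F)cc2)CC1` gives 1.59 nM, lower by more than the scatter. Compound 3 `COc1cc(C(C)=O)ccc1OCCCN1CCC(C(c2ccccc2)c2ccc(F)cc2)CC1` departs from compound 2 by fluoro in place of hydrogen on an aromatic carbon, which turns a phenyl into a 4-fluorophenyl. The expected step of a 2.0-fold lower number from compound 2 to compound 3 (0.29 log units; within the scatter) is a modest one towards a lower number. This expectation rests on compound 1 at 1.59 nM, which also bears 4-fluorophenyl. For compound 3 the estimated value is 3.2 nM, with an expected range of 1.5 nM to 6.5 nM.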

Compound 3, dissociation constant: 6.31 nM
For compound 3 the middle estimate is 2.0-fold (0.29 log units) below the measured one; the measured number falls inside the stated range.
By their numbers in this assay, from the lowest: compound 1; then compounds 2 and 3 (each within the scatter of the next).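

In this assay, a first 4-fluorophenyl in place of phenyl gives no change at the digits printed from compound 2 to compound 3 (within the scatter), so a single fluoro at this place does not separate from hydrogen. Hydrogen in place of fluoro on the doubly fluorinated compound gives a 4.0-fold higher number from compound 1 to compound 3 (0.60 log units; beyond the scatter), so among these compounds the lower number appears only with both 4-fluorophenyl groups present. Nothing available here explains why the two steps differ.

Open, from the compounds shown here alone, is whether chloro or trifluoromethyl in place of fluoro would follow compound 1 or compound 3 when present on one or both phenyl groups.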